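This account rests on a few compounds, and the source may have more. Where it says the series, first, only, none or still open, it means among the compounds named here.

Working notes on the series, all read in a functional assay on MV4-11 cells (Homo sapiens) for inhibition, read by resazurin assay, with a stated time of 72 h; on this read-out lower numbers stand for stronger inhibition of growth and higher numbers for weaker inhibition of growth. Compound 1 `O=C1NCCC12CCN(c1c(Cl)cncc1-c1ccco1)CC2` gives 940 nM. Within the data shown here, compound 2 `O=C1NCCC12CCN(c1c(Cl)cncc1-c1ccc(Cl)s1)CC2` gives 560 nM, which sits within the scatter of compound 1, the only other compound measured so far.

Compound 3 `CC(=O)c1ccc(-c2cncc(Cl)c2N2CCC3(CCNC3=O)CC2)s1` is the next to be read. The change is acetyl in place of chloro on an aromatic carbon of the five-membered aromatic ring with 1 sulfur, next to the ring sulfur, so that 5-chlorothiophen-2-yl becomes 5-acetylthiophen-2-yl.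

Among the measured compounds shown here, the only measured guide is a 1.7-fold lower number from compound 1 to compound 2 (0.22 log units; within the scatter). That step exchanged the whole aromatic group on the shared core and left the numbers within the scatter. For the measured compounds named here, no measured pair varies the group at this carbon alone, so the evidence is thin and gives no direction. In this assay, no step beyond the scatter is therefore expected, and the expected change is a 1.1-fold higher number from compound 2 to compound 3 (0.03 log units; within the scatter). For compound 3 the estimated value is 600 nM, with an expected range from 200 nM to 1800 nM.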

Compound 3, concentration for 50% growth inhibition: 1440 nM
Compound 3: the middle estimate sits 2.4-fold (0.38 log units) below what was measured; measured number inside the range.
By their numbers in this assay, from the lowest: compounds 2, 1 and 3 (each within the scatter of the next, the first and the last beyond it).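

In this assay, among these compounds, this is the first change confined to a single substituent, and it gives a step beyond the scatter: acetyl in place of chloro, on an aromatic carbon of the five-membered aromatic ring with 1 sulfur, next to the ring sulfur, gives a 2.6-fold higher number from compound 2 to compound 3 (0.41 log units; beyond the scatter), so the number at this carbon does respond to the group it carries, though the step is modest. Exchange of the whole aromatic group separates less: 5-acetylthiophen-2-yl in place of furan-2-yl gives a 1.5-fold higher number from compound 1 to compound 3 (0.19 log units; within the scatter), so those two groups cannot be told apart here. No measurement at hand accounts for the difference between chloro and acetyl at this carbon.

Open, going by these compounds, is whether the step follows the entering acetyl or the departing chloro, which a plain hydrogen, a methyl or a nitrile at this carbon would help to separate. Also open, on these data alone, is whether an amine, a carboxylic acid or a longer chain at this carbon would shift the number in either direction, and whether any group there gives a lower number than compound 2.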